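The compounds below may be only part of what the source reports. "The series", "measured", "known", "first", "only" and "open" are said of these compounds alone.

Working notes on the series, read in a functional assay on K562 cells (Homo sapiens) for cytotoxicity, read by trypan blue exclusion, with a stated time of 96 h; a lower number here means a stronger inhibitor, a higher number a weaker inhibitor. Compound 1 `COc1cc(OC)c(/C=C/S(=O)(=O)Cc2ccc(OC)c(N)c2)c(OC)c1`, with hydrogen on the nitrogen, gives 2.5 nM. Compound 2 `COC(=O)CNc1cc(CS(=O)(=O)/C=C/c2c(OC)cc(OC)cc2OC)ccc1OC` gives 100 nM, and compound 3 `COC(=O)C(C)(C)Nc1cc(CS(=O)(=O)/C=C/c2c(OC)cc(OC)cc2OC)ccc1OC` gives 800 nM, the highest number of the three and so the weakest inhibitor here. Both substituted compounds sit well above compound 1: the measured steps are a 40-fold higher number from compound 1 to compound 2 (1.60 log units; beyond the scatter) and a 320-fold higher number from compound 1 to compound 3 (2.51 log units; beyond the scatter). Between the two substituted compounds the step is an 8.0-fold higher number from compound 2 to compound 3 (0.90 log units; beyond the scatter).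

Next is compound 4 `COC(=O)C(Nc1cc(CS(=O)(=O)/C=C/c2c(OC)cc(OC)cc2OC)ccc1OC)c1ccc(Br)cc1`, with this change: (4-bromophenyl)(methoxycarbonyl)methyl in place of 1-(methoxycarbonyl)-1-methylethyl on a nitrogen on an aromatic ring. In words, (4-bromophenyl)(methoxycarbonyl)methyl stands in place of 1-(methoxycarbonyl)-1-methylethyl on a nitrogen on an aromatic ring. Among the compounds with values here, no measured compound carries an aromatic ring in this group, so no step maps directly onto the change. The closest guide is the modest 8.0-fold higher number from compound 2 to compound 3 (0.90 log units; beyond the scatter), which also exchanges one ester-bearing group for another on that nitrogen. A step of about that size or smaller is therefore expected, with the direction uncertain and a slightly lower number favoured. A return towards the 2.5 nM of compound 1 is not expected, given a 40-fold higher number from compound 1 to compound 2 (1.60 log units; beyond the scatter). The expected step is a 2.0-fold lower number from compound 3 to compound 4 (0.30 log units; within the scatter), and this is only an estimate. The estimated value for compound 4 is 400 nM, with an expected range from 80 nM to 2000 nM.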

Compound 4, half-maximal inhibitory concentration: 200 nM
Compound 4: middle estimate off by 2.0-fold (0.30 log units), on the high side, and the stated range covers the measured number.
By their numbers in this assay, from the lowest: compound 1; then compounds 2 and 4 (each within the scatter of the next); then compound 3.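

Substitution on this nitrogen accepts a much larger group than compounds 2 and 3 showed: with (4-bromophenyl)(methoxycarbonyl)methyl in place of 1-(methoxycarbonyl)-1-methylethyl, the result is a 4.0-fold lower number from compound 3 to compound 4 (0.60 log units; beyond the scatter), so the larger group does not carry a further penalty in this assay. Relative to (methoxycarbonyl)methyl, 4-bromophenyl on the saturated chain carbon gives a 2.0-fold higher number from compound 2 to compound 4 (0.30 log units; within the scatter), whereas the change to 1-(methoxycarbonyl)-1-methylethyl gives an 8.0-fold higher number from compound 2 to compound 3 (0.90 log units; beyond the scatter), so the two substituted forms of that carbon do not behave alike. Even so, the ester-bearing group with the aromatic ring does not recover the activity of the parent with hydrogen on the nitrogen, at an 80-fold higher number from compound 1 to compound 4 (1.90 log units; beyond the scatter). Nothing at hand offers a measured explanation for these differences.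

The compounds shown do not separate the contribution of the bromine from that of the aromatic ring, a question that a plain phenyl group on the same chain carbon would address. They also leave open the role of the methyl ester, as a carboxylic acid or an amide in its place lies outside this set.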